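This account rests on a few compounds, and the source may have more. Where it says the series, first, only, none or still open, it means among the compounds named here.

For the measured compounds named here, compound 2 `CN(c1cc2ncc(=O)[nH]c2cc1NC(=S)Nc1ccc(F)cc1)C1CCCCC1` stands at the higher of the two numbers so far in an ADME assay on Huh-7 cells (Homo sapiens) for cytotoxicity (a lower number here means a stronger inhibitor, a higher number a weaker inhibitor), where compound 2 gives 64300 nM. Its nearest neighbour is compound 1 `CN(c1cc2ncc(=O)[nH]c2cc1NC(=S)NC(=O)/C=C/c1ccccc1)C1CCCCC1`, which in this assay gives 11000 nM; the step between them, a 5.8-fold higher number from compound 1 to compound 2 (0.77 log units; beyond the scatter), is the only one at hand, and it comes from a swap on the same nitrogen that is changed again in compound 3 `CN(c1cc2ncc(=O)[nH]c2cc1NC(=N)NCc1ccccn1)C1CCCCC1`. That change is a group of 10 heavy atoms (7 carbon, 3 nitrogen; one six-membered aromatic ring with 1 hetero atom) in place of a group of 10 heavy atoms (7 carbon, 1 nitrogen, 1 fluorine, 1 sulfur; one six-membered aromatic ring of carbon only), on a nitrogen on an aromatic ring.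

Going by the values given here, only the single step from compound 1 to compound 2 bears on this, and it shows that exchanging the group on that nitrogen can move the number in this assay beyond the scatter, though only modestly. Nothing shows the direction for the group that now enters. He therefore expects compound 3 to stay near compound 2, with a step no larger than the one already seen and possibly within the scatter. His estimate for compound 3 in this assay is 40000 nM, between 12000 nM and 130000 nM, which means an expected step of a 1.6-fold lower number from compound 2 to compound 3 (0.21 log units; within the scatter).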

Compound 3, half-maximal inhibitory concentration: 48600 nM
Beside the measured number, compound 3's estimate is 1.2-fold (0.08 log units) below it; low and high end bracket the measured number.
By their numbers in this assay, from the lowest: compound 1; then compounds 3 and 2 (each within the scatter of the next).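

In this assay the group with a six-membered aromatic ring with 1 hetero atom, entering on a nitrogen on an aromatic ring in place of the group with a six-membered aromatic ring of carbon only, gives a 1.3-fold lower number from compound 2 to compound 3 (0.12 log units; within the scatter) and so no change that can be told apart. The earlier step had shown only that an exchange on this nitrogen can move the number beyond the scatter; this one shows that not every exchange there does, even though fluorine and sulfur both leave and the counts of hydrogen-bond donors and acceptors differ. Compound 1 gives 11000 nM and stays apart from compound 2, while compound 3 gives 48600 nM in the same assay.

Sulfur, fluorine and the ring hetero atom all change in this one step, so the compounds shown do not tell which of them, if any, matters to the number. They also leave open what a carboxylic acid, a morpholine or a longer chain on that nitrogen would give in this assay and whether any such group would come close to compound 1.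

No evidence at hand bears on this result.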